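The source may hold more compounds than are shown below. What is called first, only, known or untested is meant among the compounds shown, and "the series" means these compounds.

In a functional assay on HL-60 cells (Homo sapiens) for activation (on this read-out lower numbers stand for an effect already at smaller amounts and higher numbers for an effect only at larger amounts of compound), two compounds have been measured so far. Compound 1 (`CCCCCCCCCCCCCCNCC(N)CCCCN`) gives 251 nM, and compound 2 (`CCCCCCCCCCCCCCNC(=O)[C@@H](N)CCCCN`) gives 501 nM. For the measured compounds named here, compound 2 therefore stands within the usual scatter of compound 1, the only other compound with a number, and the pair sets no order between them.

The next compound is compound 3 (`CCCCCCCCCCCCNC(=O)[C@@H](N)CCCCN`), which differs from compound 2 at one place: hydrogen in place of ethyl on a saturated chain carbon, ten or more bonds along the chain from an amide-type nitrogen. In words, hydrogen stands in place of ethyl on a saturated chain carbon, so the chain is shorter and the rest of the structure is unchanged.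

Going by the values given here, no measured pair shows what such a change does in this assay, so the expectation rests on the structural change alone and remains uncertain. A modest shift toward a higher number is expected, possibly no larger than the scatter. The expected size of the change is a 1.4-fold higher number from compound 2 to compound 3 (0.15 log units; within the scatter). For compound 3, the estimated value is 700 nM, with an expected range from 200 nM to 2500 nM.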

Compound 3, half-maximal effective concentration: 794 nM
For compound 3 the middle estimate is 1.1-fold (0.05 log units) below the measured one; low and high end bracket the measured number.
By their numbers in this assay, from the lowest: compounds 1, 2 and 3 (each within the scatter of the next, the first and the last beyond it).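

For the compounds shown here, this pair gives the first step at this position in this assay: hydrogen in place of ethyl on a saturated chain carbon, ten or more bonds along the chain from an amide-type nitrogen, gives a 1.6-fold higher number from compound 2 to compound 3 (0.20 log units; within the scatter) and so stays within the scatter. Going by these compounds alone, removing the two carbons of that ethyl therefore leaves no readable difference in this assay, something the earlier compounds, which offered no pair differing in one place, could not show. No measurement accompanies this pair that would explain the number, so the step can be read only for its size.

Going by these compounds, it remains open whether a longer chain than that of compound 2, or a chain shorter than that of compound 3, would carry the number beyond the scatter, since a single step sets no trend along the chain. On these data alone, it is equally open what a hydroxyl, an amine or a phenyl group would do in place of ethyl at this same place on the chain.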